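The source may hold more compounds than are shown below. What is called first, only, known or untested is meant among the compounds shown, and "the series" means these compounds.

Measured compounds:
Compound 1 `CC(C)c1onc(-c2c(Cl)cccc2Cl)c1COc1ccc(N(C)Cc2cccc(C(=O)O)c2)c(C(F)(F)F)n1` gives 80 nM in a functional assay on HEK293 cells for agonist activity at Bile acid receptor (Homo sapiens); a higher number here means that more compound is needed for the effect, a lower number that less compound is needed.
Compound 2 `CC(C)c1onc(-c2c(Cl)cccc2Cl)c1COc1ccc(N(C)Cc2ccc(OCC(=O)O)cc2)c(C(F)(F)F)n1` gives 214 nM in this assay.

Compound 2 stands at the higher of the two numbers; its nearest neighbour is compound 1, and the step of a 2.7-fold higher number from compound 1 to compound 2 (0.43 log units; beyond the scatter) lies beyond the scatter. Compound 3 `CC(C)c1onc(-c2c(Cl)cccc2Cl)c1COc1ccc(N(C)Cc2ccc(OCCO)cc2)c(C(F)(F)F)n1` differs from compound 2 by hydroxymethyl in place of carboxy on a saturated chain carbon bound to an oxygen on an aromatic ring. Going by the values given here, no measured step bears directly on this change. Among the compounds with values here, the single known step, a 2.7-fold higher number from compound 1 to compound 2 (0.43 log units; beyond the scatter), exchanges one carboxy-bearing group for another and keeps a carboxy in the molecule, whereas the present change gives the carboxy up altogether. The data therefore offer no measured guide to the size or direction of the step. Compound 3 is nonetheless expected to need more compound than compound 2 in this assay, estimated at 700 nM. The estimated step is a 3.3-fold higher number from compound 2 to compound 3 (0.51 log units; beyond the scatter). The expected range for compound 3 runs from 200 nM to 3000 nM.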

Compound 3, half-maximal effective concentration: 1150 nM
Compound 3: the middle estimate sits 1.6-fold (0.22 log units) below what was measured; the measured number falls inside the stated range.
By their numbers in this assay, from the lowest: compound 1; then compound 2; then compound 3.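

In this assay, giving up the carboxy for hydroxymethyl on a saturated chain carbon bound to an oxygen on an aromatic ring brings a 5.4-fold higher number from compound 2 to compound 3 (0.73 log units; beyond the scatter) and so shows what the earlier exchange of one carboxy-bearing group for another could not: the effect of losing the carboxy altogether. Compound 3 still gives a number in this assay without any carboxy, so a carboxy is not required for a measurable value in this series. Against the 3-carboxyphenyl group, the 4-(2-hydroxyethoxy)phenyl group brings a 14-fold higher number from compound 1 to compound 3 (1.16 log units; beyond the scatter) as the widest gap among the three compounds, and no measurement at hand explains either step.

On these data alone, whether a primary amide or a tetrazole at the end of this chain would stay closer to compound 2 remains open. So does the effect of a longer chain carrying the carboxylic acid.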